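A few compounds are considered here, and "the series" means these few. Any claim that something is new, unique, unknown or untested is made for them only; others in the source may bear on it.

Of the compounds shown here, three of a shared core have been measured in a functional assay on QGY7701 cells (Homo sapiens) for cytotoxicity, read by MTT assay, with a stated time of 48 h; on this read-out higher numbers stand for weaker inhibition and lower numbers for stronger inhibition. Compound 1 `O=c1ccoc2cc(OCc3cn(Cc4cccc(F)c4)nn3)ccc12` gives a value that is only a limit of the assay, > 100000 nM. Compound 2 `O=c1ccoc2cc(OCc3cn(Cc4ccc(F)cc4)nn3)ccc12` gives 14400 nM, and compound 3 `O=c1ccoc2cc(OCc3cn(Cc4ccccc4Cl)nn3)ccc12` gives 19700 nM. The step of an at least 6.9-fold lower number from compound 1 to compound 2 (0.84 log units; beyond the scatter) and the step of an at least 5.0-fold lower number from compound 1 to compound 3 (0.70 log units; beyond the scatter) both rest on the limit set by the limit of > 100000 nM in this assay, at which 1 of the 3 values shown sits. The step of a 1.4-fold higher number from compound 2 to compound 3 (0.14 log units; within the scatter) is within the scatter, so compound 2 and compound 3 cannot be separated on these numbers; compound 3 has the higher of the two numbers, with compound 2 closest to it.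

Compound 4 `O=c1ccoc2cc(OCc3cn(Cc4ccccc4Br)nn3)ccc12` differs from compound 3 in one place: bromo in place of chloro on an aromatic carbon. No measured step exchanges one halogen for another at the same position; the three steps shown all move the halogen around the ring or swap fluoro for chloro at a different position, and of these only the step from compound 2 to compound 3 was small. The closest guide is therefore the modest spread between compound 2 and compound 3, and the expected step of a 1.2-fold lower number from compound 3 to compound 4 (0.09 log units; within the scatter) is none beyond the scatter. Compound 4 is accordingly expected to give about 16000 nM in this assay, with a range from 6000 nM to 45000 nM.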

Compound 4, half-maximal inhibitory concentration: > 100000 nM
Compound 4 gave a limit, no number (the forecaster's own chance of this, stated with the estimate: 10%); at least 6.2-fold (0.79 log units) between middle value and limit.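

In this assay, within the data shown here, the exchange of one halogen for another at a single place, which no earlier pair showed, gives an at least 5.0-fold higher number from compound 3 to compound 4 (0.70 log units; beyond the scatter) and so is far from silent on this aromatic carbon, ortho to a large group. The 2-bromophenyl group also parts compound 4 from the 4-fluorophenyl compound, with an at least 6.9-fold higher number from compound 2 to compound 4 (0.84 log units; beyond the scatter) in the same direction, so the closeness of compound 2 and compound 3 does not extend to every halogen on this benzyl ring. The value of compound 4 is a limit, as is that of compound 1, and the step between these two compounds cannot be read, because neither gives a number: the limit of > 100000 nM in this assay, at which 2 of the 4 values shown sit.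

As far as these compounds go, whether an iodo, a methyl or a methoxy group at this same place would keep a readable value, as chloro does in compound 3, or lose it, as bromo does in compound 4, stays open. Equally open, from the compounds shown here alone, is whether bromo in place of fluoro on the rings of compound 1 and compound 2 would give a number in this assay at all.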